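A few compounds are considered here, and "the series" means these few. Any claim that something is new, unique, unknown or untested is made for them only; others in the source may bear on it.

Compound 1 `ClCc1cccc(Cn2cnc3ncnc(Cl)c32)c1`: 13800 nM
Compound 2 `ClCc1ccccc1Cn1cnc2ncnc(Cl)c21`: 5370 nM
Compound 3 `ClCc1cccc(Cn2cnc3nc(Cl)nc(Cl)c32)c1`: 930 nM

All three were tested in a functional assay on EKVX cells (Homo sapiens) for cytotoxicity, read by sulforhodamine B assay, with a stated time of 48 h; on this read-out higher numbers stand for weaker inhibition of growth and lower numbers for stronger inhibition of growth. Compound 1 and compound 2 are built from the same atoms joined differently; the difference between the two cores is not broken down here. Compound 3 is compound 1 with one change, (chloro in place of hydrogen on an aromatic carbon), and that single change gave a 15-fold lower number from compound 1 to compound 3 (1.17 log units; beyond the scatter). Compound 4 `ClCc1ccccc1Cn1cnc2nc(Cl)nc(Cl)c21` has not yet been measured in this assay; it stands to compound 2 as compound 3 stands to compound 1, namely (chloro in place of hydrogen on an aromatic carbon), the same change at the same place. Within the data shown here, the step is therefore expected to be a 13-fold lower number from compound 2 to compound 4 (1.13 log units; beyond the scatter), because a 15-fold lower number from compound 1 to compound 3 (1.17 log units; beyond the scatter) is the only guide available. Compound 4 is accordingly estimated at 400 nM in this assay. Its expected range runs from 150 nM to 1200 nM for compound 4.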

Compound 4, concentration for 50% growth inhibition: 1730 nM
The estimate for compound 4 lay 4.3-fold (0.64 log units) below the measured number; measured number above the stated range.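

In this assay chloro in place of hydrogen on an aromatic carbon gives a 3.1-fold lower number from compound 2 to compound 4 (0.49 log units; beyond the scatter) and so points the same way on both cores. The direction of the step carries over, but its size does not: the same change on two cores in this assay, a 15-fold lower number (1.17 log units; beyond the scatter) from compound 1 to compound 3 and a 3.1-fold lower number (0.49 log units; beyond the scatter) from compound 2 to compound 4, 4.8-fold (0.68 log units) apart, beyond the scatter of two such steps. Among these compounds, with only two pairs of compounds, this does not show why the size differs or what the same change would do on any further core.

The compounds shown leave open what another group would do at this same place, between two ring nitrogen atoms. Among the compounds shown here, an amine or a methoxy group there could show whether chloro is the only group that lowers the number.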